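A methoxyphenyl swap on the way to compound 3

The compounds below may be only part of what the source reports. "The series", "measured", "known", "first", "only" and "open" are said of these compounds alone.

Compound 1 `COc1ccccc1C(=O)/C=C/C1=Cc2cc(Br)ccc2OC1` gives 6130 nM
Compound 2 `COc1ccc2c(c1)C=C(/C=C/C(=O)c1ccccc1OC)CO2` gives 1040 nM

In a functional assay on HCT-116 cells (Homo sapiens) for cytotoxicity, read by crystal violet staining, with a stated time of 7 days (a lower number here means a stronger inhibitor, a higher number a weaker inhibitor), compound 2 has the lower of the two numbers, at 1040 nM, making it the stronger inhibitor so far. Compound 3 `COc1ccc(C(=O)/C=C/C2=Cc3cc(OC)ccc3OC2)cc1` is still unmeasured. It differs from compound 2 as follows: 4-methoxyphenyl in place of 2-methoxyphenyl on a carbonyl carbon, with 4-methoxyphenyl in place of 2-methoxyphenyl on a carbonyl carbon. Among the measured compounds shown here, the only measured step, a 5.9-fold lower number from compound 1 to compound 2 (0.77 log units; beyond the scatter), was a different change, methoxy in place of bromo on an aromatic carbon. It shows that one swap can matter, but it gives no direction for this one. The expected result is a 1.0-fold lower number from compound 2 to compound 3 (0.02 log units; within the scatter), with neither direction favoured. For compound 3 the estimated value is 1000 nM (range 280 nM to 3600 nM) .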

Compound 3, half-maximal inhibitory concentration: 7950 nM
Compound 3: the middle estimate sits 8.0-fold (0.90 log units) below what was measured; measured number outside the range, above it.
By their numbers in this assay, from the lowest: compound 2; then compounds 1 and 3 (each within the scatter of the next).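

Exchanging 2-methoxyphenyl for 4-methoxyphenyl on the carbonyl carbon gives a 7.6-fold higher number from compound 2 to compound 3 (0.88 log units; beyond the scatter), so this part of the molecule, the same in compound 1 and compound 2, also affects the result. Compound 2 and compound 3 hold the same atoms, joined differently, so a rearrangement alone is enough to produce a step beyond the scatter. Nothing available explains why the numbers differ. Still open, from the compounds shown here alone, is how an amine or a carboxylic acid on that phenyl ring would read. Also open, going by these compounds, is whether the same exchange gives a similar step when the core carries the bromo group of compound 1.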